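The source may hold more compounds than are shown below. What is called first, only, known or untested is meant among the compounds shown, and "the series" means these compounds.

Three sulfonamides built on the same core have been tested in an assay on isolated protein for inhibition of malate dehydrogenase, mitochondrial (Sus scrofa), with stated times of 45 min and 30 min; on this read-out higher numbers stand for weaker inhibition and lower numbers for stronger inhibition. Compound 1 `O=S(=O)(Nc1ccc(-c2nc3ccccc3o2)cc1)c1cccs1` carries a thiophen-2-yl on its sulfonyl sulfur. In this assay compound 1 gives a value that is a limit of the measurement rather than a number, > 63000 nM. Compound 2 `O=S(=O)(Nc1ccc2oc(-c3ccccc3)nc2c1)c1ccccc1C(F)(F)F` likewise gives only a limit, > 63000 nM. Compound 3 `Cc1cccc(S(=O)(=O)Nc2ccc3oc(-c4ccccc4)nc3c2)c1` too reaches only a limit, > 63000 nM. All three values shown therefore sit at the limit of > 63000 nM in this assay, at which 3 of the 3 values shown sit, and compound 1 stands with the others: each of them is a limit, not a number. Compound 4 `C=Cc1ccc(S(=O)(=O)Nc2ccc(-c3nc4ccccc4o3)cc2)cc1` has not yet been measured. It differs from compound 1 in one place: 4-vinylphenyl in place of thiophen-2-yl on a sulfonyl sulfur. Among the measured compounds shown here, no step between measured compounds is on hand to lean on. The step is expected to be a step that the limit leaves unreadable from compound 1 to compound 4, that is, no change beyond the usual scatter, because compound 1 itself already shows only a limit at the limit of > 63000 nM in this assay, at which 3 of the 3 values shown sit. Compound 4 is therefore expected to give about 80000 nM, within a range from 30000 nM to 250000 nM, and most likely again only a limit.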

Compound 4, half-maximal inhibitory concentration: > 63000 nM
Compound 4 gave a limit, no number (the forecaster's own chance of this, stated with the estimate: 85%); the middle value lies beyond the limit too.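

Compound 1 and compound 4 each give only a limit, not a number, so no step can be read between them: the limit of > 63000 nM in this assay, at which 4 of the 4 values shown sit.

The compounds shown leave open whether 4-vinylphenyl in place of thiophen-2-yl changes inhibition at all, and whether any related sulfonamide gives a true number in this assay.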